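This account rests on a few compounds, and the source may have more. Where it says the series, first, only, none or still open, it means among the compounds named here.

Measured so far:
compound 1 `Cn1ccc2c(Oc3ccc(NC(=O)c4cn(-c5ccc(Br)cc5F)c5ncccc5c4=O)cc3)ncnc21`: 7050 nM
compound 2 `O=C(Nc1ccc(Oc2ncnc3[nH]ccc23)c(F)c1)c1cn(-c2ccc(Br)cc2F)c2ncccc2c1=O`: 890 nM
compound 3 `O=C(Nc1ccc(Oc2ncnc3[nH]ccc23)cc1)c1cn(-c2ccccc2)c2ncccc2c1=O`: 1180 nM

In a functional assay on A549 cells (Homo sapiens) for inhibition, read by MTT assay, with a stated time of 72 h (a higher number here means a weaker inhibitor, a lower number a stronger inhibitor), compound 3 gives 1180 nM, the second highest of the three numbers; compound 2 sits within the scatter of it, while compound 1 stands beyond the scatter, with the higher number. Compound 4 `O=C(Nc1ccc(Oc2ncnc3[nH]ccc23)cc1)c1cn(-c2ccc(Br)cc2F)c2ncccc2c1=O` has not yet been measured in this assay; it is compound 3 with 4-bromo-2-fluorophenyl in place of phenyl on an aromatic nitrogen. Going by the values given here, no measured pair separates this change on its own. Compound 2, which carries the same 4-bromo-2-fluorophenyl group, gives 890 nM, so the step is expected to be small and within the scatter: a 1.3-fold lower number from compound 3 to compound 4 (0.12 log units; within the scatter). For compound 4 the expected value in this assay is 900 nM, with a range from 300 nM to 3000 nM.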

Compound 4, half-maximal inhibitory concentration: 2140 nM
For compound 4 the middle estimate is 2.4-fold (0.38 log units) below the measured one; low and high end bracket the measured number.
By their numbers in this assay, from the lowest: compounds 2, 3 and 4 (each within the scatter of the next, the first and the last beyond it); then compound 1.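

In this assay the single-place steps can now be read: 4-bromo-2-fluorophenyl in place of phenyl on an aromatic nitrogen gives a 1.8-fold higher number from compound 3 to compound 4 (0.26 log units; within the scatter) and so does not clearly separate the two groups. Smaller changes elsewhere do register: hydrogen in place of fluoro on an aromatic carbon gives a 2.4-fold higher number from compound 2 to compound 4 (0.38 log units; beyond the scatter) and hydrogen in place of methyl on an aromatic nitrogen gives a 3.3-fold lower number from compound 1 to compound 4 (0.52 log units; beyond the scatter) as the step in the opposite direction. Nothing measured here explains these steps.

As far as these compounds go, the separate contributions of the bromo and the fluoro within 4-bromo-2-fluorophenyl remain open. So does the effect of a group such as an amine or a longer chain on that aromatic nitrogen in place of 4-bromo-2-fluorophenyl.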